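Adding a 4-chlorophenyl to the amide of compound 2

A few compounds are considered here, and "the series" means these few. Any claim that something is new, unique, unknown or untested is made for them only; others in the source may bear on it.

Of the compounds shown here, three sharing a thio-substituted core have been measured in a functional assay on MCF7 cells (Homo sapiens) for inhibition, read by sulforhodamine B assay, with a stated time of 48 h; a higher number here means a weaker inhibitor of growth, a lower number a stronger inhibitor of growth. Compound 1 `O=CN1CCN(c2ccc(Cl)cc2)C1=S` gives 2800 nM, compound 3 `O=CN1CCN(C(=O)c2ccco2)C1=S` gives 2700 nM, and compound 2 `N#C/C(=C\N1CCN(C(=O)c2ccco2)C1=S)C(N)=O` gives 1700 nM. The number for compound 2 is the lowest of the three, but its gaps to compound 3 and to compound 1 both lie within the usual scatter, so no order among them can be read.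

Compound 4 `N#C/C(=C\N1CCN(C(=O)c2ccco2)C1=S)C(=O)Nc1ccc(Cl)cc1` differs from compound 2 in one place: 4-chlorophenyl in place of hydrogen on an amide-type nitrogen. Among the measured compounds shown here, no measured pair shows what such a change does here, so the expected step in this assay is uncertain, and at most a modest one in either direction. Compound 4 is expected to give about 1200 nM, within 400 nM to 4000 nM, an estimated step of a 1.4-fold lower number from compound 2 to compound 4 (0.15 log units; within the scatter).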

Compound 4, concentration for 50% growth inhibition: 21000 nM
Compound 4: the middle estimate sits 18-fold (1.24 log units) below what was measured; measured number outside the range, above it.
By their numbers in this assay, from the lowest: compounds 2, 3 and 1 (each within the scatter of the next); then compound 4.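

In this assay, the amide hydrogen of compound 2 is not a neutral place to build on: 4-chlorophenyl on that nitrogen gives a large step, a 12-fold higher number from compound 2 to compound 4 (1.09 log units; beyond the scatter), towards weaker inhibition of growth. Among the compounds shown here, this position therefore responds strongly to what it carries, which the earlier compounds could not show. No measurement here explains the rise.

Still open, from the compounds shown here alone, is whether any group on this nitrogen has the same effect or whether it belongs to this one. A methyl, a longer chain or an unsubstituted phenyl there would help to tell these apart.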